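The source may report more compounds than this note shows. Statements on the series, on what has been measured and on what is new or still open speak of the compounds shown alone.

Three compounds share one core and differ only in the group carried by a nitrogen on an aromatic ring. In an assay on isolated protein for inhibition of protein kinase C delta type (Homo sapiens), read by TR-FRET, with a stated time of 2 h (a higher number here means a weaker inhibitor, a lower number a stronger inhibitor), compound 3, `CC1(C)C[C@H](Nc2cc(NCc3cnccc3C(F)(F)F)ncc2C#N)CC[C@@H]1O`, gives 500 nM, the lowest of the two numbers obtained. Compound 2, `N#Cc1cnc(NCc2cnccc2C(F)(F)F)cc1NCC1CCOCC1`, gives 5000 nM in this assay. Compound 1, `N#Cc1cnc(NCc2cnccc2C(F)(F)F)cc1NC[C@H]1C[C@H](O)C1`, reaches only a limit of the assay, > 10000 nM. The measured steps are an at least 2.0-fold lower number from compound 1 to compound 2 (0.30 log units; that floor lies within the scatter), an at least 20-fold lower number from compound 1 to compound 3 (1.30 log units; beyond the scatter) and a 10-fold lower number from compound 2 to compound 3 (1.00 log units; beyond the scatter).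

Compound 4, `CC1(C)[C@H](Nc2cc(NCc3cnccc3C(F)(F)F)ncc2C#N)C[C@H]1C(N)=O`, makes a further change in the same position: 3-carbamoyl-2,2-dimethylcyclobutyl in place of 4-hydroxy-3,3-dimethylcyclohexyl on a nitrogen on an aromatic ring. Going by the values given here, all the measured steps bear on it, since each also swapped the group on that nitrogen, and each moved the number by at least a modest amount. The new ring is smaller than that of compound 3 and carries a carbamoyl rather than a hydroxyl, so some loss of the gain seen in compound 3 is expected, with the step estimated as a 3.0-fold higher number from compound 3 to compound 4 (0.48 log units; beyond the scatter). Compound 4 is therefore expected to give about 1500 nM, within a range from 300 nM to 8000 nM.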

Compound 4, half-maximal inhibitory concentration: 900 nM
Beside the measured number, compound 4's estimate is 1.7-fold (0.22 log units) above it, and the stated range covers the measured number.
By their numbers in this assay, from the lowest: compounds 3 and 4 (each within the scatter of the next); then compound 2. At a limit, above all of these: compound 1.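

Moving from 4-hydroxy-3,3-dimethylcyclohexyl to 3-carbamoyl-2,2-dimethylcyclobutyl changes the ring size and the polar group together, yet in this assay the result is a 1.8-fold higher number from compound 3 to compound 4 (0.26 log units; within the scatter) and the two compounds cannot be told apart. The gain over the oxane group also survives this change, with a 5.6-fold lower number from compound 2 to compound 4 (0.74 log units; beyond the scatter), so among the compounds shown the two groups carrying a ring dimethyl pair give the lowest numbers. Compound 1 gives only a limit, so an at least 11-fold lower number from compound 1 to compound 4 (1.04 log units; beyond the scatter) is a floor and not a measured size: the limit of > 10000 nM in this assay, at which 1 of the 4 values shown sits.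

Ring size and the carbamoyl changed in a single step, so their separate contributions remain unknown. Also open, from the compounds shown here alone, are whether the dimethyl pair matters, as a plain 3-carbamoylcyclobutyl would show, and whether a carboxylic acid or an amine could take the place of the carbamoyl.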